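This account rests on a few compounds, and the source may have more. Where it says the series, first, only, none or still open, it means among the compounds named here.

Series notes. In a functional assay on NCI-H226 cells (Homo sapiens) for inhibition, read by MTT assay, with a stated time of 48 h, tested at 10 uM (on this read-out higher numbers stand for more inhibition at the one concentration tested (going by the name of the read-out) and lower numbers for less inhibition), compound 1 `COc1cc(NC(=O)Nc2cc(Nc3cc(C)cc(F)c3)ncn2)cc(OC)c1` gives 35.3% and compound 2 `COc1cc(NC(=O)Nc2cc(Nc3ccc(F)c(Cl)c3)ncn2)cc(OC)c1` gives 36.7%; compound 2 stands alongside compound 1, the two numbers within the scatter of each other. Compound 3 `CCc1ccc(Nc2cc(NC(=O)Nc3cc(OC)cc(OC)c3)ncn2)cc1` differs from compound 2 by 4-ethylphenyl in place of 3-chloro-4-fluorophenyl on a nitrogen on an aromatic ring. Among the compounds with values here, the only measured step at this nitrogen on an aromatic ring is a number 1.4 percentage points higher from compound 1 to compound 2 (within the scatter), which bears directly on the present change. Because that step a number 1.4 percentage points higher from compound 1 to compound 2 (within the scatter) stayed within the scatter, the step of a number 1.7 percentage points lower from compound 2 to compound 3 (within the scatter) is expected to stay within the scatter as well. Compound 3 is therefore estimated at 35%, range 20% to 50%.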

Compound 3, a percentage reported as inhibition, at one concentration (the size of the read-out at that concentration, not a potency): 50.1%
Compound 3: middle estimate off by 15.1 percentage points, on the low side; the measured number lies above the stated range.
By their numbers in this assay, from the lowest: compounds 1 and 2 (each within the scatter of the next); then compound 3.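

In this assay the group on this nitrogen on an aromatic ring does move the number: 4-ethylphenyl gives a number 13.4 percentage points higher from compound 2 to compound 3 (beyond the scatter) against 3-chloro-4-fluorophenyl and a number 14.8 percentage points higher from compound 1 to compound 3 (beyond the scatter) against 3-fluoro-5-methylphenyl. Within the data shown here, the one earlier step at this place stayed within the scatter, so these two modest steps are the first beyond it. Both point the same way, with 4-ethylphenyl over either halogen-bearing ring.

Open, from the compounds shown here alone, is whether the ethyl group itself or the absence of halogen goes with the higher number, and what a longer chain such as propyl or an amine on the same phenyl ring would give. No measurement at hand accounts for the difference.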